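The compounds below may be only part of what the source reports. "The series", "measured", "known", "first", "only" and "open" are said of these compounds alone.

Measured compounds in this set:
- compound 1 `Clc1ccc2[nH]c(SCc3ccccc3Oc3ccccc3)nc2c1`: 30%
- compound 2 `Clc1ccc2sc(SCc3ccccc3CCc3ccccc3)nc2c1`: 9%
- compound 3 `c1ccc(CCc2ccccc2CSC2=NCCS2)cc1`: 0%

All three were run in an assay on isolated protein for inhibition of Indoleamine 2,3-dioxygenase 1 (Homo sapiens), with a stated time of 60 min, tested at 10 uM; on this read-out higher numbers stand for more inhibition at the one concentration tested (going by the name of the read-out) and lower numbers for less inhibition. Compound 1 gives the highest of the three numbers; compound 2 sits lower by a step beyond the scatter, and compound 3 lies further down still, also beyond the scatter. Among the measured compounds shown here, with no single-point steps between measured compounds available, nothing in the set isolates the effect of any one change.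

The next compound is compound 4 `Clc1ccc2[nH]c(SCc3ccccc3CCCc3ccccc3)nc2c1`. Relative to compound 1 the change is 3-phenylpropyl in place of phenoxy on an aromatic carbon, sitting on an aromatic carbon of a six-membered aromatic ring of carbon only, ortho to a large group. The shared core of compound 1 is kept; only the pendant group on that aromatic carbon is exchanged. Compound 2 and compound 3, which carry a phenethyl-type pendant on different cores, both give low numbers, so a modest drop in this assay from compound 1 to compound 4 is expected, of roughly a number 10 percentage points lower from compound 1 to compound 4 (within the scatter). Compound 4 is therefore estimated at 20%, within a range from 5% to 38%.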

Compound 4, a percentage reported as inhibition, at one concentration (the size of the read-out at that concentration, not a potency): 19%
Beside the measured number, compound 4's estimate is 1 percentage points above it, within the range that was stated.
By their numbers in this assay, from the lowest: compounds 3, 2 and 4 (each within the scatter of the next, the first and the last beyond it); then compound 1.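

Among the compounds shown here, at the aromatic carbon ortho to a large group, this is the first comparison that isolates a single change: on the shared core of compound 1, 3-phenylpropyl in place of phenoxy gives a modest step in this assay (a number 11 percentage points lower from compound 1 to compound 4 (beyond the scatter)). The oxygen of phenoxy is thus not required for a reading at this place, as the all-carbon pendant of compound 4 still gives 19% at the one concentration tested. No measured evidence bears on the reason for the step.

Open, on these data alone, is how a benzyloxy or phenethyl pendant on the core of compound 1 would read, which would separate the oxygen from the chain length. Also open, as far as these compounds go, is whether an amine or a carboxylic acid at the end of the 3-phenylpropyl chain would shift the number.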